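Taking the Chloro Off Compound 1

The compounds below may be only part of what the source reports. "The series", "measured", "known", "first", "only" and "open" are said of these compounds alone.

In a physicochemical assay for lipophilicity, at pH 7.4 (on this read-out lower numbers stand for lower lipophilicity and higher numbers for higher lipophilicity), compound 1 `COc1cccc(C(=O)NCc2c(C)cc(C)[nH]c2=O)c1Cl` stands lowest of three measured compounds at 1.2, below compound 2 `Cc1cc(C)c(CNC(=O)c2cccc(OC(C)C)c2Cl)c(=O)[nH]1` at 2 and compound 3 `Cc1cc(C)c(CN2CCc3c(Cl)cc(-c4c(C)n[nH]c4C)c(Cl)c3C2=O)c(=O)[nH]1` at 3.4. Compound 4 `COc1cccc(C(=O)NCc2c(C)cc(C)[nH]c2=O)c1` differs from compound 1 in one place: hydrogen in place of chloro on an aromatic carbon, which is hydrogen in place of chloro on an aromatic carbon. Going by the values given here, no measured pair loses a chloro. The closest guide is a number 0.80 log units higher from compound 1 to compound 2 (beyond the scatter), which came with isopropyl in place of methyl on an oxygen on an aromatic ring, so it offers only a rough size. A downward step, somewhat smaller than that one, is expected in this assay. The expected change is a number 0.50 log units lower from compound 1 to compound 4 (beyond the scatter). For compound 4 the estimate is 0.7, within an expected range from 0.3 to 1.1.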

Compound 4, distribution coefficient: 1.7
Beside the measured number, compound 4's estimate is 1.00 log units below it; measured number outside the range, above it.
By their numbers in this assay, from the lowest: compound 1; then compounds 4 and 2 (each within the scatter of the next); then compound 3.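

In this assay, going by these compounds alone, the swap of this chloro for hydrogen, on a carbon ortho to a methoxy group, gives a number 0.50 log units higher from compound 1 to compound 4 (beyond the scatter) as the only measured step at this position. In this one pair, then, losing the chloro raises the number rather than lowering it. No measurement shown here accounts for that direction.

On these data alone, whether the same step appears with isopropyl on the oxygen, as in compound 2, remains open. So does what an amine or a nitrile on this carbon would give.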